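A few compounds are considered here, and "the series" means these few. Any claim that something is new, unique, unknown or untested is made for them only; others in the source may bear on it.

Working notes on the series. In a functional assay on MDA-MB-468 cells (Homo sapiens) for inhibition, read by sulforhodamine B assay, with a stated time of 48 h, tested at 10 uM (a lower number here means less inhibition of growth, a higher number more inhibition of growth at the concentration tested), compound 1 (`CC(=O)c1cccc(Nc2ccnc(SCC(=O)c3ccc(-c4ccccc4)cc3)n2)c1`) gives 14%. For the measured compounds named here, its only measured neighbour is compound 2 (`CC(=O)c1ccc(Nc2ccnc(SCC(=O)c3ccc(-c4ccccc4)cc3)n2)cc1`), which gives 13%. The two lie within the scatter of each other, so compound 1 has no distinct standing on these numbers.

The unmeasured compound 3 (`CC(=O)c1cccc(Nc2ccnc(SCC(=O)c3ccc(C(F)(F)F)cc3)n2)c1`) differs from compound 1 as follows: trifluoromethyl in place of phenyl on an aromatic carbon. In words, this is trifluoromethyl in place of phenyl on an aromatic carbon, para to a large group.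

Going by the values given here, the only measured step is a number 1 percentage points lower from compound 1 to compound 2 (within the scatter). That step concerns the group on nitrogen and leaves the phenyl untouched, so it bears only indirectly on this change. Among the compounds with values here, no measured step shows what replacing the phenyl does, and the uncertainty is therefore wide. With compound 1 at 14% as the sole anchor, no step beyond the scatter is expected in this assay. The expected step is a number 2 percentage points lower from compound 1 to compound 3 (within the scatter), an estimate that stays within the scatter. Compound 3 is estimated at 12%, with an expected range of 0% to 32%.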

Compound 3, percent growth inhibition at one concentration: 16%
The estimate for compound 3 lay 4 percentage points below the measured number; the range from low to high includes it.
By their numbers in this assay, from the lowest: compounds 2, 1 and 3 (each within the scatter of the next).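

In this assay, trifluoromethyl in place of phenyl on an aromatic carbon, para to a large group, gives a number 2 percentage points higher from compound 1 to compound 3 (within the scatter). Compound 1 and compound 2 differ only in the group on nitrogen and so said nothing about this position; this pair shows that, between these two groups, exchanging a six-membered aromatic ring of carbon only with 6 heavy atoms for a ringless group with 4 heavy atoms leaves the read-out without a distinct change at the concentration tested. No measurement at hand bears on why the numbers for this pair stand so close.

The compounds shown leave open whether any other group on this aromatic carbon, such as a carboxylic acid, a dimethylamino group or a longer alkyl chain, would move growth inhibition beyond the scatter. They also leave open whether trifluoromethyl in place of phenyl would give a similar outcome with the group on nitrogen of compound 2, or in other cell lines.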